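Compound 3 to compound 4: methoxy replaced by an amide

The source may report more compounds than this note shows. Statements on the series, on what has been measured and on what is new or still open speak of the compounds shown alone.

- compound 1 `N#Cc1ccc(-c2cc(F)c3ncc(Cc4ccc5ncccc5c4)n3c2)cn1` gives 189 nM
- compound 2 `N#Cc1cccc(-c2cc(F)c3ncc(Cc4ccc5ncccc5c4)n3c2)c1` gives 107 nM
- compound 3 `COc1ccc(-c2cc(F)c3ncc(Cc4ccc5ncccc5c4)n3c2)cc1F` gives 407 nM

In a functional assay on EBC-1 cells (Homo sapiens) for antiproliferative activity, with a stated time of 72 h (a higher number here means a weaker inhibitor, a lower number a stronger inhibitor), compound 3 gives the highest number of the three, with a 2.2-fold higher number from compound 1 to compound 3 (0.33 log units; beyond the scatter) and a 3.8-fold higher number from compound 2 to compound 3 (0.58 log units; beyond the scatter) both modest. Compound 4 `CN1CCN(C(=O)c2ccc(-c3cc(F)c4ncc(Cc5ccc6ncccc6c5)n4c3)cc2F)CC1` carries (4-methylpiperazin-1-yl)carbonyl in place of methoxy on an aromatic carbon and is otherwise unchanged from compound 3. Within the data shown here, no measured step makes this exact change. Those two steps replace the whole group on the same aromatic carbon of the core, so they give only a rough size. Compound 3 at 407 nM sits at the top of this small range, so a modest fall is expected. The expected step is an estimated 2.4-fold lower number from compound 3 to compound 4 (0.38 log units; beyond the scatter) in this assay and a result within the scatter would not surprise. For compound 4 the estimate is 170 nM with a range of 50 nM to 500 nM on this thin basis.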

Compound 4, half-maximal inhibitory concentration: 869 nM
The estimate for compound 4 lay 5.1-fold (0.71 log units) below the measured number; measured number above the stated range.
By their numbers in this assay, from the lowest: compounds 2 and 1 (each within the scatter of the next); then compound 3; then compound 4.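

In this assay, replacing methoxy with (4-methylpiperazin-1-yl)carbonyl, on the aromatic carbon ortho to a fluoro group, gives a 2.1-fold higher number from compound 3 to compound 4 (0.33 log units; beyond the scatter). This position therefore tolerates a group of 9 heavy atoms carrying a six-membered non-aromatic ring, with only a modest step and no gain over methoxy. No measurement on hand bears on the reason for this step.

The compounds shown do not separate the contribution of the carbonyl from that of the piperazine ring. A primary amide, a carboxylic acid or a morpholine-4-carbonyl group on this carbon would address that question.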